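Methylated pyrazole replacing phenyl in an antiproliferative series

The source may report more compounds than this note shows. Statements on the series, on what has been measured and on what is new or still open speak of the compounds shown alone.

Measured compounds:
compound 1 `CNC(=O)N1CCCc2ccc(NC(=O)c3ccc(-c4cc[nH]n4)cc3)cc21`: 99.1%
compound 2 `CNC(=O)N1CCCc2ccc(NC(=O)c3ccc(-c4ccccc4)cc3)cc21`: 74.3%

In a functional assay on MV4-11 cells (Homo sapiens) for antiproliferative activity, with a stated time of 6 days, tested at 6.25 uM (a lower number here means a weaker effect, a higher number a stronger effect of the compound at the concentration tested), compound 2 gives the lower of the two numbers, and its nearest neighbour is compound 1, which in this assay gives 99.1%. Compound 3 `CNC(=O)N1CCCc2ccc(NC(=O)c3ccc(-c4ccn(C)n4)cc3)cc21` differs from compound 2 in one place: 1-methyl-1H-pyrazol-3-yl in place of phenyl on an aromatic carbon. For the measured compounds named here, the only measured step that bears on this change is a number 24.8 percentage points lower from compound 1 to compound 2 (beyond the scatter), where the pyrazolyl of compound 1 gave way to phenyl. Compound 3 reverses that exchange in part, bringing back a pyrazol-3-yl that now carries a methyl on nitrogen. A gain in this assay is therefore expected, probably a good share of that earlier step, though the methylated ring need not reproduce the value of compound 1 fully. For compound 3 the estimated step is a number 13.7 percentage points higher from compound 2 to compound 3 (beyond the scatter), giving an expected value of 88% with a range from 70% to 100%.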

Compound 3, a percentage reported as inhibition, at one concentration (the size of the read-out at that concentration, not a potency): 97%
Estimate against measurement, compound 3: 9 percentage points below; the measured number falls inside the stated range.
By their numbers in this assay, from the lowest: compound 2; then compounds 3 and 1 (each within the scatter of the next).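

Replacing phenyl with 1-methyl-1H-pyrazol-3-yl on this aromatic carbon, para to a large group, gives a number 22.7 percentage points higher from compound 2 to compound 3 (beyond the scatter) in this assay, so the earlier gap to phenyl is not unique to the unsubstituted pyrazole. Methyl in place of hydrogen on the aromatic nitrogen gives a number 2.1 percentage points lower from compound 1 to compound 3 (within the scatter), which shows that the hydrogen on that ring nitrogen is not needed to keep the read-out at this level. Nothing shown here accounts for the difference between either pyrazole and phenyl.

Going by these compounds, whether a longer group on that nitrogen, such as ethyl or isopropyl, or a different ring, such as pyridine or imidazole, would hold the read-out remains open. With only one concentration tested, it is also unknown whether compound 1 and compound 3 would separate at lower concentrations.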